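The source may hold more compounds than are shown below. What is called first, only, known or untested is meant among the compounds shown, and "the series" means these compounds.

Of the compounds shown here, three sharing one core have been measured in a functional assay for antagonist activity at corticotropin-releasing factor receptor 1 (Rattus norvegicus); on this read-out lower numbers stand for stronger inhibition and higher numbers for weaker inhibition. Compound 1 `CCCC(C)n1c(=O)c(C)nc2c(-c3ccc(Cl)cc3Cl)ccnc21` gives 62 nM. Compound 2 `CC[C@H](C1CC1)n1c(=O)c(C)nc2c(-c3cc(F)c(OC)cc3Cl)ccnc21` gives 1.7 nM, and compound 3 `CC[C@H](C1CC1)n1c(=O)c(C)nc2c(-c3ccc(OC)nc3C)ccnc21` gives 76 nM. Among these three numbers compound 1 stands second highest; its value and that of compound 3 lie within the scatter of each other, while compound 2 sits well apart with a clearly lower number. Compound 4 `Cc1nc2c(-c3ccc(Cl)cc3Cl)ccnc2n(CC(C)C)c1=O` has not yet been measured. It differs from compound 1 in one place: isobutyl in place of 1-methylbutyl on an aromatic nitrogen. Going by the values given here, no measured pair here shows this kind of change, so its effect in this assay is unknown. The step of a 1.9-fold higher number from compound 1 to compound 4 (0.29 log units; within the scatter) is expected to be small, toward a higher number, hardly beyond the scatter. Compound 4 is therefore estimated at 120 nM, in a range from 40 nM to 400 nM.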

Compound 4, half-maximal inhibitory concentration: 3500 nM
Beside the measured number, compound 4's estimate is 29-fold (1.46 log units) below it; the measured number lies above the stated range.
By their numbers in this assay, from the lowest: compound 2; then compounds 1 and 3 (each within the scatter of the next); then compound 4.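

The position on the aromatic nitrogen proves far more sensitive than the small size of the change suggests. In this assay, isobutyl in place of 1-methylbutyl gives a 56-fold higher number from compound 1 to compound 4 (1.75 log units; beyond the scatter), although the group only goes from 5 heavy atoms to 4 and neither has a ring or any hydrogen-bond donors or acceptors. Going by these compounds alone, nothing available explains why so slight a change moves the number so far.

Still open, as far as these compounds go, is how a straight butyl chain, a longer chain or a benzyl group would behave on this nitrogen. From the compounds shown here alone, it is also open whether the same change would have as large an effect on the core of compound 2.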